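A few compounds are considered here, and "the series" means these few. Any claim that something is new, unique, unknown or untested is made for them only; others in the source may bear on it.

Measured compounds:
compound 1 `COc1cc(OC)c(-c2coc3cc(OCC=C(C)C)ccc3c2=O)cc1OC` — 3500 nM
compound 2 `COc1cc(OC)c(-c2coc3cc(OCc4cccc(Cl)c4)ccc3c2=O)cc1OC` — > 10000 nM, a limit
compound 3 `COc1cc(OC)c(-c2coc3cc(OCc4ccccc4Cl)ccc3c2=O)cc1OC` — > 10000 nM, a limit

For the measured compounds named here, in a functional assay on U-251 cells (Homo sapiens) for antiproliferative activity, read by MTT assay, with a stated time of 24 h (a higher number here means a weaker inhibitor, a lower number a stronger inhibitor), compound 1 gives 3500 nM, the only number in the set. Compound 2 reaches only the limit > 10000 nM. Compound 3 likewise reaches only the limit > 10000 nM. Compound 1 therefore stands as the sole numbered point, with both aryl-substituted analogues sitting at the limit of > 10000 nM in this assay, at which 2 of the 3 values shown sit.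

Compound 4 `COc1cc(OC)c(-c2coc3cc(OCc4ccccc4Br)ccc3c2=O)cc1OC` differs from compound 1 by 2-bromophenyl in place of 2-methylprop-1-en-1-yl on a saturated chain carbon bound to an oxygen on an aromatic ring. Going by the values given here, the steps that bear on it are an at least 2.8-fold higher number from compound 1 to compound 2 (0.45 log units; beyond the scatter) and an at least 2.8-fold higher number from compound 1 to compound 3 (0.45 log units; beyond the scatter), each beyond the scatter and each ending at the limit. Between compound 2 and compound 3, a step that the two limits leave unreadable from compound 2 to compound 3. The change to compound 4 is of the same kind as the change to compound 3, a halogen-bearing phenyl in the same place, so a step of at least modest size toward a higher number is expected in this assay, most likely again ending at the limit.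

Compound 4 is expected to give 15000 nM, within 7000 nM to 40000 nM. This estimate corresponds to a 4.3-fold higher number from compound 1 to compound 4 (0.63 log units; beyond the scatter).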

Compound 4, half-maximal inhibitory concentration: > 10000 nM
Compound 4 was reported as a limit; the forecaster's own chance of this, stated with the estimate: 70%; the middle value lies beyond the limit too.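

In this assay, the change to 2-bromophenyl on the saturated chain carbon gives an at least 2.8-fold higher number from compound 1 to compound 4 (0.45 log units; beyond the scatter), so a second halogen, bromo in place of chloro on an aromatic carbon, also fails to return a numbered value. The steps from compound 3 to compound 4 and from compound 2 to compound 4 cannot be read, as compound 2, compound 3 and compound 4 are all reported as limits. Compound 1, with its 3-methylbut-2-en-1-yl group, therefore remains the only numbered point in the series: the limit of > 10000 nM in this assay, at which 3 of the 4 values shown sit.

The compounds shown do not separate the contribution of the phenyl ring from that of its halogen, and an unsubstituted benzyl group would address that question. Also open, on these data alone, is how a longer chain such as geranyl or a chain ending in a dimethylamine would read out at this oxygen.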